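The source may hold more compounds than are shown below. What is called first, only, known or untested is meant among the compounds shown, and "the series" means these compounds.

Measured compounds:
compound 1 `COc1cc(COc2cc(N)c(Cl)cc2C(=O)CCCCN2CCC(C)CC2)cc(OC)c1`, which in a functional assay for antagonist activity at 5-hydroxytryptamine receptor 4 (Rattus norvegicus) (a higher number here means a more potent compound, by a factor of ten per unit of this negative logarithm, a lower number a less potent compound), gives 8.3;
compound 2 `COc1cc(COc2cc(N)c(Cl)cc2C(=O)CCCCN2CCC(CNS(C)(=O)=O)CC2)cc(OC)c1`, which in this assay gives 8.9;
compound 3 `COc1cc(COc2cc(N)c(Cl)cc2C(=O)CCCCN2CCC(CCNS(C)(=O)=O)CC2)cc(OC)c1`, which in this assay gives 8.1.

Among these three, compound 1 holds the middle number: compound 3 lies close to it, the step of a number 0.20 log units lower from compound 1 to compound 3 (within the scatter) staying within the scatter, whereas compound 2 stands clearly higher, the step of a number 0.60 log units higher from compound 1 to compound 2 (beyond the scatter) lying beyond it.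

Compound 4 `CCCCN1CCC(CCC(=O)c2cc(Cl)c(N)cc2OCc2cc(OC)cc(OC)c2)CC1` differs from compound 1 in a different way from anything measured so far: 1-butylpiperidin-4-yl in place of 2-(4-methylpiperidin-1-yl)ethyl on a saturated chain carbon, two bonds along the chain from a carbonyl carbon. Among the compounds with values here, the three measured steps all concern what hangs on the saturated ring carbon of the piperidine, not how the piperidine is joined to the chain, so none of them bears directly on this change, and the data give no step of the same kind to lean on. The expectation for compound 4 in this assay therefore rests on compound 1 alone and carries a wide margin; an estimated step of a number 0.50 log units lower from compound 1 to compound 4 (beyond the scatter) is foreseen, with compound 4 expected at 7.8, between 6.8 and 8.8.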

Compound 4, negative logarithm of the antagonist equilibrium constant: 8.9
Beside the measured number, compound 4's estimate is 1.10 log units below it, and the stated range ends below it.
By their numbers in this assay, from the lowest: compounds 3 and 1 (each within the scatter of the next); then compounds 2 and 4 (each within the scatter of the next).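

In this assay, the step of a number 0.60 log units higher from compound 1 to compound 4 (beyond the scatter) shows that this position tolerates more than changes to what hangs on the ring. The earlier steps shown here all kept the 2-(4-methylpiperidin-1-yl)ethyl attachment, whereas 1-butylpiperidin-4-yl joins the piperidine to the chain differently and the number still rises beyond the scatter. Compound 4 also achieves this rise without a methanesulfonamido group, so that group is not the only change shown to raise the number from compound 1. No measurement given here accounts for the rise.

The swap alters the butyl group and the point of attachment together, so the contribution of each remains unresolved. On these data alone, it also remains open how a propyl or pentyl group in place of that butyl would read in this assay.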